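The compounds below may be only part of what the source reports. "The series", "measured", "known", "first", "only" and "open" are said of these compounds alone.

Measured so far in an ADME assay on microsomes from liver (Homo sapiens) for metabolic stability, with a stated time of 10 min; on this read-out lower numbers stand for a less stable compound and higher numbers for a more stable compound:
- compound 1 `Cc1c(Cl)cccc1Oc1cccn2c(C34CCC(CC3)C4)nnc12`: 69%
- compound 2 `COC1(c2nnc3c(Oc4cccc(Cl)c4C)cccn23)CCCCCC1`: < 1% (a limit of the assay, not a number)

Compound 2 stands at the limit of < 1% in this assay, at which 1 of the 2 values shown sits. Compound 3 `Cc1c(Cl)cccc1Oc1cccn2c(C3CCC(C)(O)CC3)nnc12` has not yet been measured and differs from compound 2 in one place: 4-hydroxy-4-methylcyclohexyl in place of 1-methoxycycloheptyl on an aromatic carbon. The 1-methoxycycloheptyl group leaves, and 4-hydroxy-4-methylcyclohexyl takes its place on the same aromatic carbon.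

Among the compounds with values here, only one measured step bears on this change: a number at least 68 percentage points lower from compound 1 to compound 2 (beyond the scatter). That large drop came with the arrival of the 1-methoxycycloheptyl group, which compound 3 no longer carries. Compound 3 shares the rest of its structure with compound 1, but its new group has not been tested, and a single step is thin evidence.

The expected change is a number at least 59 percentage points higher from compound 2 to compound 3 (beyond the scatter), a large rise in this assay. For compound 3 the estimate is 60%, with an expected range of 25% to 88%.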

Compound 3, percent of the compound remaining: 99%
Compound 3: middle estimate off by 39 percentage points, on the low side, and the stated range ends below it.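

In this assay, putting 4-hydroxy-4-methylcyclohexyl in place of 1-methoxycycloheptyl on this aromatic carbon gives a number at least 98 percentage points higher from compound 2 to compound 3 (beyond the scatter). Compound 2 stands at a limit of the assay, not at a number: the limit of < 1% in this assay, at which 1 of the 3 values shown sits. The new group also goes past the two-ring carbon group of compound 1, with a number 30 percentage points higher from compound 1 to compound 3 (beyond the scatter), so the group at this position can move the read-out well beyond what the first two compounds showed, and a single-ring group can do this.

The compounds shown leave open which part of the change matters, as the ring size, the methoxy and the hydroxy group all change in one step. From the compounds shown here alone, how a plain cyclohexyl, a 1-methoxycyclohexyl or a 4-aminocyclohexyl group would read at this carbon also stays open.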